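Halogen Exchange on a Cytidine Triphosphate P2Y2 Agonist

A few compounds are considered here, and "the series" means these few. Any claim that something is new, unique, unknown or untested is made for them only; others in the source may bear on it.

Measured so far:
compound 1, `O=c1[nH]/c(=N\OCCOc2ccccc2)ccn1[C@@H]1O[C@H](COP(=O)(O)OP(=O)(O)OP(=O)(O)O)[C@@H](O)[C@H]1O`, gives 3400 nM in a functional assay on 1321-N1 cells for agonist activity at P2Y purinoceptor 2 (Homo sapiens), read by scintillation counting and inositol phosphate accumulation; a higher number here means that more compound is needed for the effect, a lower number that less compound is needed
compound 2, `O=c1[nH]/c(=N\OCCCc2ccc(F)cc2)ccn1[C@@H]1O[C@H](COP(=O)(O)OP(=O)(O)OP(=O)(O)O)[C@@H](O)[C@H]1O`, gives 547 nM in this assay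

Going by the values given here, compound 2 holds the lower of the two numbers; its only neighbour is compound 1, and the step of a 6.2-fold lower number from compound 1 to compound 2 (0.79 log units; beyond the scatter) lies beyond the scatter. Compound 3, `O=c1[nH]/c(=N\OCCCc2ccc(Br)cc2)ccn1[C@@H]1O[C@H](COP(=O)(O)OP(=O)(O)OP(=O)(O)O)[C@@H](O)[C@H]1O`, differs from compound 2 by bromo in place of fluoro on an aromatic carbon. Among the compounds with values here, the one measured step bears only loosely on this: it exchanges the whole side chain, not one halogen for another, so it offers no direct guide to the size of this change. Lacking a comparable step, the change is expected to fall within or close to the scatter, in either direction. Compound 3 is therefore expected to give about 400 nM, with a range from 150 nM to 1200 nM, which means a step of a 1.4-fold lower number from compound 2 to compound 3 (0.14 log units; within the scatter) in this assay.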

Compound 3, half-maximal effective concentration: 350 nM
Compound 3: the middle estimate sits 1.1-fold (0.06 log units) above what was measured; measured number inside the range.
By their numbers in this assay, from the lowest: compounds 3 and 2 (each within the scatter of the next); then compound 1.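

In this assay, bromo in place of fluoro on the aromatic carbon para to a large group gives a 1.6-fold lower number from compound 2 to compound 3 (0.19 log units; within the scatter), so this exchange does not separate compound 2 from compound 3. The lower number seen with the fluorinated side chain therefore does not depend on fluoro alone: the side-chain change read with bromo gives a 9.7-fold lower number from compound 1 to compound 3 (0.99 log units; beyond the scatter), which like the earlier step lies beyond the scatter. The data shown offer no measurement that would explain either step.

On these data alone, whether chloro, methoxy or a plain hydrogen on the same aromatic carbon would also fall alongside compound 2 and compound 3 remains open. Also open, as far as these compounds go, is whether a longer chain carrying the 4-bromophenyl group would keep the number as low as that of compound 3.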